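The source may report more compounds than this note shows. Statements on the series, on what has been measured and on what is new or still open speak of the compounds shown alone.

Compound 1 `N#Cc1cccc(-n2cc(COc3cccc(NC(=O)Nc4ccc(Cl)c(C(F)(F)F)c4)c3)nn2)c1` gives 2760 nM in a functional assay on HepG2 cells (Homo sapiens) for inhibition, read by MTT assay, with a stated time of 72 h; a lower number here means a stronger inhibitor, a higher number a weaker inhibitor. Compound 2 `CCc1cccc(-n2cc(COc3cccc(NC(=O)Nc4ccc(Cl)c(C(F)(F)F)c4)c3)nn2)c1` gives 37900 nM in this assay, the highest of the two numbers known here; the one step shown, a 14-fold higher number from compound 1 to compound 2 (1.14 log units; beyond the scatter), is large. Compound 3 `CC(C)c1ccc(-n2cc(COc3cccc(NC(=O)Nc4ccc(Cl)c(C(F)(F)F)c4)c3)nn2)cc1` differs from compound 2 by 4-isopropylphenyl in place of 3-ethylphenyl on an aromatic nitrogen. Within the data shown here, no measured step swaps one alkyl-bearing phenyl for another, so the step from compound 1 to compound 2 offers no direct guide, and compound 3 is expected to stay close to compound 2 with a step of a 1.3-fold lower number from compound 2 to compound 3 (0.10 log units; within the scatter). Compound 3 is estimated at 30000 nM, within 8000 nM to 120000 nM.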

Compound 3, half-maximal inhibitory concentration: 2470 nM
The estimate for compound 3 lay 12-fold (1.08 log units) above the measured number; the measured number lies below the stated range.
By their numbers in this assay, from the lowest: compounds 3 and 1 (each within the scatter of the next); then compound 2.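

The aryl group on the aromatic nitrogen does not need the nitrile to reach the better numbers in this assay, since a 15-fold lower number from compound 2 to compound 3 (1.19 log units; beyond the scatter) shows an alkyl-bearing phenyl recovering the loss seen with 3-ethylphenyl. Also, a 1.1-fold lower number from compound 1 to compound 3 (0.05 log units; within the scatter) places 4-isopropylphenyl level with 3-cyanophenyl, so alkyl substitution alone does not account for the weak number of compound 2. Nothing available here explains this step.

Because group and ring position change together from compound 2 to compound 3, their separate contributions remain unresolved. On these data alone, how an amine or a carboxylic acid on this phenyl would fare also stays open.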